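Methyl in Place of Methoxy: From Compound 1 to Compound 4

A few compounds are considered here, and "the series" means these few. Any claim that something is new, unique, unknown or untested is made for them only; others in the source may bear on it.

Compound 1 `COc1ccc(CO/N=C/c2c(C)nn(C)c2Oc2ccc(Cl)cc2)cc1`: 43.9%
Compound 2 `Cc1c(CO/N=C/c2c(-c3ccccc3)nn(-c3ccccc3)c2Oc2ccc(Cl)cc2)cccc1-c1ccccc1`: -10.1%
Compound 3 `Cc1nn(-c2ccccc2)c(Oc2ccc(Cl)cc2)c1/C=N/OCc1ccc(C(=O)OC(C)(C)C)cc1`: -6.5%

In a functional assay on A549 cells (Homo sapiens) for antiproliferative activity, tested at 1 uM (a lower number here means less inhibition, a higher number more inhibition at the concentration tested (going by the name of the read-out)), compound 1 gives 43.9%, the highest of the three numbers; compound 3 lies beyond the scatter below it, and compound 2 lies furthest below, also beyond the scatter. Compound 4 `Cc1ccc(CO/N=C/c2c(C)nn(C)c2Oc2ccc(Cl)cc2)cc1` has not been measured. It differs from compound 1 in a single place: methyl in place of methoxy on an aromatic carbon. For the measured compounds named here, no measured pair shows this change, so its size must be judged from the change alone, a small one on the 4-methoxybenzyl group. Compound 4 is therefore expected to remain close to compound 1, with an estimated step of a number 5.9 percentage points lower from compound 1 to compound 4 (within the scatter) that stays within the scatter and leans slightly downward. For compound 4 the estimated value is 38%, with a range from 15% to 60%.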

Compound 4, a percentage reported as inhibition, at one concentration (the size of the read-out at that concentration, not a potency): 50%
Estimate against measurement, compound 4: 12 percentage points below; low and high end bracket the measured number.
By their numbers in this assay, from the lowest: compounds 2 and 3 (each within the scatter of the next); then compounds 1 and 4 (each within the scatter of the next).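

In this assay, for the compounds shown here, the change from 4-methoxybenzyl to 4-methylbenzyl gives the first direct reading at this position, with a number 6.1 percentage points higher from compound 1 to compound 4 (within the scatter) on the shared core. The hydrogen-bond acceptor of the methoxy group is thus not required here for the inhibition at this concentration, since compound 4, which lacks it, gives 50%. Nothing at hand bears on why the two groups read alike. From the compounds shown here alone, whether an amine or a carboxylic acid at this place would hold the inhibition stays open. A single pair also cannot show whether the same change would read alike on another core.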